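Pentyloxy for diethylamino on the carbonyl carbon

A few compounds are considered here, and "the series" means these few. Any claim that something is new, unique, unknown or untested is made for them only; others in the source may bear on it.

Compound 1 (`CC(C)(C)c1cc(-c2cc(=O)c3ccc(OCc4ccc5ccccc5n4)cc3o2)cc(C(C)(C)C)c1O`), compound 2 (`CCOC(=O)COc1ccc2c(=O)cc(-c3cc(C(C)(C)C)c(O)c(C(C)(C)C)c3)oc2c1`) and compound 3 (`CCN(CC)C(=O)COc1ccc2c(=O)cc(-c3cc(C(C)(C)C)c(O)c(C(C)(C)C)c3)oc2c1`) share a core. In a functional assay for inhibition (a higher number here means a weaker inhibitor, a lower number a stronger inhibitor), compound 1 gives 3000 nM, compound 2 gives 3000 nM and compound 3 gives 3000 nM, so compound 3 stands level with the other two.

Compound 4 (`CCCCCOC(=O)COc1ccc2c(=O)cc(-c3cc(C(C)(C)C)c(O)c(C(C)(C)C)c3)oc2c1`) is still unmeasured. It carries pentyloxy in place of diethylamino on a carbonyl carbon.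

The closest measured change is at the same place, diethylamino in place of ethoxy, and it gives no change at the digits printed from compound 2 to compound 3 (within the scatter). The two replacements of quinolin-2-yl give no change at the digits printed from compound 1 to compound 2 (within the scatter) and no change at the digits printed from compound 1 to compound 3 (within the scatter). None of the three steps leaves the scatter. Going by the values given here, no measured compound carries pentyloxy, so the range is kept wide.

No step beyond the scatter is expected in either direction in this assay, and the expected step is no change at the digits printed from compound 3 to compound 4 (within the scatter).

Compound 4 is estimated at 3000 nM, with an expected range from 1400 nM to 6000 nM.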

Compound 4, half-maximal inhibitory concentration: 5000 nM
Beside the measured number, compound 4's estimate is 1.7-fold (0.22 log units) below it; low and high end bracket the measured number.
By their numbers in this assay, from the lowest: compounds 1, 2, 3 and 4 (each within the scatter of the next).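

In this assay, pentyloxy on the carbonyl carbon gives a 1.7-fold higher number from compound 3 to compound 4 (0.22 log units; within the scatter), so this exchange of diethylamino for an ester group extends the flat picture to a longer alkoxy chain. The chain itself adds no step beyond the scatter, with a 1.7-fold higher number from compound 2 to compound 4 (0.22 log units; within the scatter) for pentyloxy against ethoxy, and the exchange of quinolin-2-yl for pentyloxycarbonyl gives a 1.7-fold higher number from compound 1 to compound 4 (0.22 log units; within the scatter), so all four compounds now sit within the scatter of one another. No supporting data bear on this result.

Going by these compounds alone, still open is whether any group at this place can move the number beyond the scatter, since no step so far gives a direction. A free carboxylic acid or a basic amine on the saturated chain carbon would test this, as would a chain longer than pentyloxy.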